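Lengthening the Acid Chain of a Prostacyclin Receptor Agonist

This account rests on a few compounds, and the source may have more. Where it says the series, first, only, none or still open, it means among the compounds named here.

Compound 2 `O=C(O)CC[C@@H]1CC[C@@H]2[C@@H](/C=C/[C@@H](O)COc3ccccc3)[C@H](O)C[C@@H]2OC1` carries a carboxylic acid chain on a saturated ring carbon of the shared core. In an ADME assay on CHO cells for agonist activity at prostacyclin receptor (Homo sapiens), read by HTRF and cAMP accumulation (a lower number here means that less compound is needed, a higher number that more compound is needed for the effect), compound 2 gives only a limit, > 10000 nM. Its stereoisomer compound 3 `O=C(O)CC[C@H]1CC[C@@H]2[C@@H](/C=C/[C@@H](O)COc3ccccc3)[C@H](O)C[C@@H]2OC1` likewise reaches only a limit in this assay, > 10000 nM. The step that the two limits leave unreadable from compound 2 to compound 3 cannot be read because of the limit of > 10000 nM in this assay, at which 3 of the 3 values shown sit, even though the two compounds differ in nothing else, as the fact that compounds 2 and 3 differ only in the configuration as drawn states. Compound 1 `O=C(O)CCCCCC1=CC[C@@H]2[C@@H](/C=C/[C@@H](O)COc3ccccc3)[C@H](O)C[C@@H]2OC1`, with a double bond in the ring, also shows only a limit in this assay, > 10000 nM.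

Compound 4 `O=C(O)CCCC[C@@H]1CC[C@@H]2[C@@H](/C=C/[C@@H](O)COc3ccccc3)[C@H](O)C[C@@H]2OC1` differs from compound 2 by 2-carboxyethyl in place of carboxy on a saturated chain carbon, two bonds along the chain from a saturated ring carbon. Within the data shown here, no measured step touches this chain: the single measured step, a step that the two limits leave unreadable from compound 2 to compound 3, is unreadable, and every value so far sits at the limit. The expectation for the step that the limit leaves unreadable from compound 2 to compound 4 is therefore no readable change, with a considerable chance that compound 4 again returns only a limit. Compound 4 is expected to give about 15000 nM in this assay, estimated between 3000 nM and 60000 nM.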

Compound 4, half-maximal effective concentration: > 10000 nM
Compound 4 gave a limit, no number; the forecaster's own chance of this, stated with the estimate: 65%; the middle value is on the limit's open side.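

Compound 4 gives only a limit in this assay, > 10000 nM, so the step from compound 2 to compound 4 cannot be read, with no number on either side: the limit of > 10000 nM in this assay, at which 4 of the 4 values shown sit.

Whether 2-carboxyethyl in place of carboxy changes the concentration needed at all stays open, as does how far any of these compounds lies beyond that limit.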